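The source may report more compounds than this note shows. Statements on the series, on what has been measured and on what is new or still open speak of the compounds shown alone.

Measured in a functional assay on CCRF-CEM cells (Homo sapiens) for antiproliferative activity, with a stated time of 72 h; on this read-out higher numbers stand for weaker inhibition and lower numbers for stronger inhibition:
- compound 1 `OC[C@H]1O[C@@H](n2cnc3c(NCc4ccccc4Cl)ncnc32)[C@H](O)[C@@H]1O`: 14500 nM
- compound 2 `Cc1cccc(CNc2ncnc3c2ncn3[C@@H]2O[C@H](CO)[C@@H](O)[C@H]2O)c1`: 19100 nM
- compound 3 `OC[C@H]1O[C@@H](n2cnc3c(NCc4ccc(F)c(Cl)c4)ncnc32)[C@H](O)[C@@H]1O`: 3400 nM

Compound 1 sits at the upper end of this small range, with a 1.3-fold higher number from compound 1 to compound 2 (0.12 log units; within the scatter) and a 4.3-fold lower number from compound 1 to compound 3 (0.63 log units; beyond the scatter). The next compound, compound 4 `OC[C@H]1O[C@@H](n2cnc3c(NCc4ccccc4OC(F)(F)F)ncnc32)[C@H](O)[C@@H]1O`, carries trifluoromethoxy in place of chloro on an aromatic carbon, ortho to a large group: trifluoromethoxy in place of chloro on an aromatic carbon.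

Among the measured compounds shown here, no measured step makes this exact exchange, so the evidence is indirect. The three measured steps each replace the whole substituted phenyl group. They give a 1.3-fold higher number from compound 1 to compound 2 (0.12 log units; within the scatter) at one extreme and a 5.6-fold lower number from compound 2 to compound 3 (0.75 log units; beyond the scatter) at the other, and the two larger steps both lead to compound 3. Compound 4 does not share the substitution of compound 3, so the step seen with compound 2 is the closer guide. No step beyond the scatter is therefore expected in this assay, and no direction can be favoured with confidence. The expected step is a 1.2-fold lower number from compound 1 to compound 4 (0.08 log units; within the scatter). For compound 4 the estimated value is 12000 nM, with an expected range from 5000 nM to 26000 nM.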

Compound 4, half-maximal inhibitory concentration: > 166000 nM
Compound 4: a limit, no number (the forecaster's own chance of this, stated with the estimate: 12%); middle value at least 13-fold (1.14 log units) from the limit.
By their numbers in this assay, from the lowest: compound 3; then compounds 1 and 2 (each within the scatter of the next). At a limit, above all of these: compound 4.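

In this assay, trifluoromethoxy in place of chloro on an aromatic carbon, ortho to a large group, gives an at least 11-fold higher number from compound 1 to compound 4 (1.05 log units; beyond the scatter). This single exchange moves the number further than any exchange of the whole substituted phenyl group among compounds 1, 2 and 3, so the outcome at this position depends strongly on the group placed there, which those earlier steps did not show. The result for compound 4 is a limit of the assay and not a number, so the true size of the step stays unknown: the limit of > 166000 nM in this assay, at which 1 of the 4 values shown sits.

The compounds shown leave open whether a smaller oxygen-linked group such as methoxy at this same place would behave like chloro or like trifluoromethoxy. They also leave open whether a trifluoromethyl group, which lacks the linking oxygen, would give a number near that of compound 1.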